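The compounds below may be only part of what the source reports. "The series", "measured", "known", "first", "only" and "open" are said of these compounds alone.

Compound 1 `O=C1COc2ccc(-c3cnc(Cl)c(NS(=O)(=O)c4ccc(F)cc4)c3)cc2N1c1ccc(F)cc1` gives 32600 nM in a functional assay on MCF7 cells (Homo sapiens) for antiproliferative activity, read by MTT assay, with a stated time of 72 h; on this read-out higher numbers stand for weaker inhibition and lower numbers for stronger inhibition. Compound 2 `COc1ccc(N2C(=O)COc3ccc(-c4ccc(O)cc4)cc32)cc1` gives 17300 nM in this assay. Compound 3 `COc1ncc(-c2ccc3c(c2)N(c2ccc(F)cc2)C(=O)CO3)cc1NS(=O)(=O)c1ccc(F)cc1` is reported in this assay only as > 40000 nM, a limit of the assay rather than a number. Among the measured compounds shown here, the one measured step, an at least 1.2-fold higher number from compound 1 to compound 3 (0.08 log units; that floor lies within the scatter), ends at the limit of > 40000 nM in this assay, at which 1 of the 3 values shown sits. Compound 4 `COc1cccc(N2C(=O)COc3ccc(-c4cnc(OC)c(NS(=O)(=O)c5ccc(F)cc5)c4)cc32)c1` differs from compound 3 by 3-methoxyphenyl in place of 4-fluorophenyl on an amide-type nitrogen in a ring. For the measured compounds named here, no measured step changes the group on the amide-type nitrogen; compound 2 differs from compound 4 in more than one place, so its value informs only loosely. The step of a number no higher from compound 3 to compound 4 (the limit leaves the size open) is therefore expected to be small, with no clear direction beyond the scatter. Compound 4 is estimated at 40000 nM, between 15000 nM and 100000 nM.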

Compound 4, half-maximal inhibitory concentration: > 40000 nM
Compound 4: a limit, no number; the forecaster's own chance of this, stated with the estimate: 50%; the middle value sits exactly at the limit.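

Among the compounds shown here, compound 3 and compound 4 both stand at a limit in this assay, so no step between them can be read: the limit of > 40000 nM in this assay, at which 2 of the 4 values shown sit. On these data alone, whether 3-methoxyphenyl in place of 4-fluorophenyl on the amide-type nitrogen changes the read-out stays open.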